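A few compounds are considered here, and "the series" means these few. Any claim that something is new, unique, unknown or untested is made for them only; others in the source may bear on it.

In an assay on isolated protein for agonist activity at Bile acid receptor (Homo sapiens), read by AlphaScreen, with a stated time of 30 min (a lower number here means a smaller maximal response, a higher number a larger maximal response), compound 1 `Cc1nn(-c2ccccc2Cl)c2c1C(c1ccc(Oc3ccccc3)cc1)SC(C)C(=O)N2` gives 57%. Compound 2 `COc1ccccc1-c1ccc([C@H]2S[C@@H](C)C(=O)Nc3c2c(C)nn3-c2ccccc2C)cc1` in this assay gives 50%, the lower of the two numbers shown, yet within the scatter of compound 1. Compound 3 `Cc1ccccc1-n1nc(C)c2c1NC(=O)[C@H](C)S[C@@H]2c1ccc(-c2ccccc2)cc1` has not yet been measured in this assay. It differs from compound 2 in one place: hydrogen in place of methoxy on an aromatic carbon. Within the data shown here, no measured pair shows what this change does, so the size of the step is unknown; a step no larger than the scatter is expected, as no change at the digits printed from compound 2 to compound 3 (within the scatter). For compound 3 the estimate in this assay is 50%, within a range from 35% to 65%.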

Compound 3, largest response reached (reported as efficacy), in percent of the reference or control that the assay uses: 24%
Compound 3: middle estimate off by 26 percentage points, on the high side; the measured number lies below the stated range.
By their numbers in this assay, from the lowest: compound 3; then compounds 2 and 1 (each within the scatter of the next).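

In this assay, among these compounds, the change from 2-methoxyphenyl to phenyl gives the first readable step: a number 26 percentage points lower from compound 2 to compound 3 (beyond the scatter). At this aromatic carbon, the maximal response therefore depends on the group present, and the compound carrying methoxy has the larger response of this pair. Nothing measured here accounts for the step.

As far as these compounds go, it remains open whether a hydroxyl, an amine or a fluorine on this carbon would keep the response of compound 2. Also open, from the compounds shown here alone, is whether a longer chain, such as ethoxy, would raise or lower it.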